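Swapping methyl for bromo on a potent lead

A few compounds are considered here, and "the series" means these few. Any claim that something is new, unique, unknown or untested is made for them only; others in the source may bear on it.

Measured compounds:
- compound 1, `CCCCCc1cc(Nc2ccc(OC)cc2)cc(=O)o1`: 10.1 uM
- compound 2, `Cc1ccc(Nc2cc(-c3ccccc3)oc(=O)c2)cc1`: 0.064 uM
- compound 3, `COc1ccc(Nc2cc(-c3ccco3)oc(=O)c2)cc1`: 2.66 uM

The three measured compounds were tested in a functional assay on KB cells (Homo sapiens) for cytotoxicity, read by MTT assay, with a stated time of 72 h; on this read-out lower numbers stand for an effect already at smaller amounts and higher numbers for an effect only at larger amounts of compound. Compound 2 stands lowest of the three numbers; compound 3 sits closest to it and compound 1 furthest away, both well beyond the scatter. Among the compounds with values here, the only measured step, a 3.8-fold lower number from compound 1 to compound 3 (0.58 log units; beyond the scatter), concerns a different part of the structure. Compound 4, `O=c1cc(Nc2ccc(Br)cc2)cc(-c2ccccc2)o1`, is reached from compound 2 by the change (bromo in place of methyl on an aromatic carbon). Within the data shown here, no measured step bears on this change, so the only guide is the value of compound 2 itself. Compound 4 is therefore expected to stay close to compound 2, with the step of a 1.6-fold higher number from compound 2 to compound 4 (0.19 log units; within the scatter) likely within the scatter. The estimate for compound 4 is 0.1 uM, in the range 0.02 uM to 0.5 uM.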

Compound 4, concentration for half-maximal effect: 0.32 uM
Beside the measured number, compound 4's estimate is 3.2-fold (0.51 log units) below it; measured number inside the range.
By their numbers in this assay, from the lowest: compound 2; then compound 4; then compound 3; then compound 1.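

Putting bromo in place of methyl at this position, para to a large group, is not a neutral exchange: in this assay the change gives a 5.0-fold higher number from compound 2 to compound 4 (0.70 log units; beyond the scatter) and so moves the number modestly beyond the scatter. This position therefore responds to the group it carries, even though the two groups each count one heavy atom and no hydrogen-bond donors or acceptors. Nothing measured here explains the difference between methyl and bromo. 

Going by these compounds, what a chloro group, an amine or a carboxylic acid would do at this position remains open. On these data alone, it is also open whether the same exchange would give a similar step with pentyl or furan-2-yl on the core.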